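Swapping one halogenated ring in a set of limits

The source may hold more compounds than are shown below. What is called first, only, known or untested is meant among the compounds shown, and "the series" means these compounds.

In a functional assay on U-251 cells (Homo sapiens) for inhibition, read by MTT assay, with a stated time of 2 days (a higher number here means that more compound is tolerated, a lower number that less compound is tolerated), compound 1 `Nc1ccccc1NC(=O)CCCNCC(=O)Nc1cccc(Cl)c1` gives > 100000 nM, which is a limit and not a number. Compound 2 `Nc1ccccc1NC(=O)CCCNCC(=O)Nc1ccc(Br)cc1` gives > 100000 nM, also a limit. Compound 3 `Nc1ccccc1NC(=O)c1ccc(NCC(=O)Nc2ccc([N+](=O)[O-])cc2)cc1` gives > 100000 nM, again a limit. Compound 2 therefore has no exact value to start from, only the same limit as the other two.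

Compound 4 `Nc1ccccc1NC(=O)CCCNCC(=O)Nc1ccccc1Cl` differs from compound 2 by 2-chlorophenyl in place of 4-bromophenyl on an amide-type nitrogen. Going by the values given here, the one measured step that bears on this swap is a step that the two limits leave unreadable from compound 1 to compound 2, which also exchanged the halogenated ring on that nitrogen. It gives no size to carry over. Among the compounds with values here, the only guide is the limit of > 100000 nM in this assay, at which 3 of the 3 values shown sit, so compound 4 is expected to behave like the others in this assay, most likely returning a limit as well. What is expected is a number no higher from compound 2 to compound 4 (the limit leaves the size open), with no size beyond the usual scatter. For compound 4 the estimated value is 100000 nM, with an expected range of 50000 nM to 200000 nM.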

Compound 4, concentration lethal to 50% of the cells: > 100000 nM
Compound 4: only a limit was reported (the forecaster's own chance of this, stated with the estimate: 85%); the middle value sits exactly at the limit.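

In this assay compound 4 gives > 100000 nM, which is again a limit and not a number. The steps to compound 4 from compound 1 and from compound 2 therefore cannot be read. The compounds shown leave open whether changing the halogenated ring on the amide-type nitrogen alters the result at all, since the exact value of each compound remains unknown.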